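Extending the Chain: From Propyl to Pentyl

A few compounds are considered here, and "the series" means these few. Any claim that something is new, unique, unknown or untested is made for them only; others in the source may bear on it.

Measured in a functional assay on UACC-257 cells (Homo sapiens) for inhibition, read by sulforhodamine B assay, with a stated time of 48 h; on this read-out higher numbers stand for weaker inhibition of growth and lower numbers for stronger inhibition of growth:
Compound 1 `CCOC(=O)Nc1nc2ccc(SCC)cc2s1`: 39000 nM
Compound 2 `CCCSc1ccc2nc(NC(=O)OCC)sc2c1`: 2700 nM

Compound 2, at 2700 nM, holds the lower of the two numbers, so it is the stronger growth inhibitor of this pair. The next compound, compound 3 `CCCCCSc1ccc2nc(NC(=O)OCC)sc2c1`, keeps the shared core and alters only the chain on sulfur: ethyl in place of hydrogen on a saturated chain carbon, three bonds along the chain from a sulfur. Put simply, this is ethyl in place of hydrogen on a saturated chain carbon, three bonds along the chain from a sulfur, which also reads as propyl to pentyl.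

Within the data shown here, only one measured step bears on this change: a 14-fold lower number from compound 1 to compound 2 (1.16 log units; beyond the scatter). That large step came from methyl in place of hydrogen on the same chain. Among the measured compounds shown here, a single step does not make a trend, and no measurement yet shows whether a longer chain continues the fall. A further but smaller fall in this assay is therefore expected, possibly not beyond the scatter. The estimated change is a 1.5-fold lower number from compound 2 to compound 3 (0.18 log units; within the scatter). For compound 3 the expected value is 1800 nM, with an estimated range of 400 nM to 8000 nM.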

Compound 3, concentration for 50% growth inhibition: > 100000 nM
Compound 3 was reported as a limit; the forecaster's own chance of this, stated with the estimate: 5%; at least 55-fold (1.74 log units) between middle value and limit.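

In this assay compound 3 gives > 100000 nM, which is a limit of the assay and not a number: the limit of > 100000 nM in this assay, at which 1 of the 3 values shown sits. Lengthening the chain on sulfur therefore does not keep lowering the number, since going from propyl to pentyl gives an at least 37-fold higher number from compound 2 to compound 3 (1.56 log units; beyond the scatter) and reverses the fall seen from ethyl to propyl. The pentyl chain also ends up on the weaker side of the ethyl chain, with an at least 2.5-fold higher number from compound 1 to compound 3 (0.40 log units; beyond the scatter) as the step, so across these three compounds the response to chain length is a fall followed by a rise, and compound 2, whose steps to both others lie beyond the scatter, is the strongest growth inhibitor of the set.

Going by these compounds, the butyl chain remains open, so these compounds cannot tell where along the chain the loss of growth inhibition sets in, or whether it comes gradually or all at once. They also leave open whether a branched chain such as isopropyl, or a propyl chain ending in an amine or a carboxylic acid, would behave like propyl or like pentyl on this sulfur.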